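Swapping a thiourea for a dichlorophenyl urea

The source may hold more compounds than are shown below. What is called first, only, known or untested is meant among the compounds shown, and "the series" means these compounds.

Of the compounds shown here, three have been tested in a functional assay on HeLa cells (Homo sapiens) for inhibition, read by CCK-8 assay, with a stated time of 48 h; a higher number here means a weaker inhibitor, a lower number a stronger inhibitor. Compound 1 `O=C(NCCNS(=O)(=O)c1ccc(-c2ccccc2O[C@H]2CC[C@H](O)CC2)s1)Nc1cc(Cl)cc(Cl)c1` gives > 20000 nM, which is a limit of the assay rather than a number. Compound 2 `Nc1ccc(Oc2ccccc2-c2ccc(S(=O)(=O)NCCNC(=O)Nc3ccc(Cl)cc3)s2)cc1` likewise gives > 20000 nM, again only a limit. For the measured compounds named here, compound 3 `O=S(=O)(NCCNC(=S)Nc1cccc(Cl)c1)c1ccc(-c2ccccc2OCc2ccccc2)s1` gives 8400 nM, the only actual number among the three. The other two values rest at a limit (the limit of > 20000 nM in this assay, at which 2 of the 3 values shown sit).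

Compound 4 `O=C(NCCNS(=O)(=O)c1ccc(-c2ccccc2OCc2ccccc2)s1)Nc1cc(Cl)cc(Cl)c1` differs from compound 3 in one place: a group of 11 heavy atoms (7 carbon, 1 nitrogen, 1 oxygen, 2 chlorine; one six-membered aromatic ring of carbon only) in place of a group of 10 heavy atoms (7 carbon, 1 nitrogen, 1 sulfur, 1 chlorine; one six-membered aromatic ring of carbon only), on an amine nitrogen. Compound 4 shares its (3,5-dichlorophenyl)carbamoyl group with compound 1, whereas compound 3 carries a different group on that amine nitrogen. Since compound 1 sits at the limit, the expected outcome for compound 4 is a weaker inhibitor than compound 3, with a fair chance that only a limit is reported. The step from the measured value is expected to be a 1.8-fold higher number from compound 3 to compound 4 (0.25 log units; within the scatter). Compound 4 is estimated at 15000 nM, within a range from 5000 nM to 40000 nM.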

Compound 4, half-maximal inhibitory concentration: > 20000 nM
Compound 4: no number, only a limit; the forecaster's own chance of this, stated with the estimate: 45%; middle value at least 1.3-fold (0.12 log units) away from the limit.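

In this assay, placing (3,5-dichlorophenyl)carbamoyl on the amine nitrogen, in place of the group with a sulfur and a single chlorine, gives an at least 2.3-fold higher number from compound 3 to compound 4 (0.37 log units; beyond the scatter). For the compounds shown here, this is the first readable comparison in the set, and it shows that the group at this position matters when the benzyl group on the oxygen stays the same. Compound 4 gives only a limit and not a number, so the real step could be larger, and compound 4 joins the other compounds at that limit: the limit of > 20000 nM in this assay, at which 3 of the 4 values shown sit.

The step from compound 1 to compound 4 cannot be read, as both values are limits. As far as these compounds go, the change replaces sulfur with oxygen and adds a second chlorine in one move, so it remains open which of the two matters, and how a carboxylic acid on that aromatic ring would behave.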